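The source may report more compounds than this note shows. Statements on the series, on what has been measured and on what is new or still open speak of the compounds shown alone.

Compound 1 `C#CCSc1nc(Nc2ccccc2)c2ccncc2n1` is the parent of this small set. In a functional assay on PC-3 cells (Homo sapiens) for inhibition, read by MTT assay, with a stated time of 72 h (on this read-out lower numbers stand for stronger inhibition and higher numbers for weaker inhibition), compound 1 gives > 80000 nM, which is a limit of the assay rather than a number. Compound 2 `C#CCSc1nc(Nc2ccc(F)cc2)c2ccncc2n1` gives 17300 nM in this assay, and the step of an at least 4.6-fold lower number from compound 1 to compound 2 (0.66 log units; beyond the scatter) is the only readable gain among the three. Compound 3 `C#CCSc1nc(Nc2ccccc2Cl)c2ccncc2n1` gives > 80000 nM in this assay, again a limit. The step that the two limits leave unreadable from compound 1 to compound 3 cannot be sized because of the limit of > 80000 nM in this assay, at which 2 of the 3 values shown sit. The step of an at least 4.6-fold higher number from compound 2 to compound 3 (0.66 log units; beyond the scatter) runs the other way. Compound 4 `C#CCSc1nc(Nc2cccc(Cl)c2)c2ccncc2n1` differs from compound 1 in one place: chloro in place of hydrogen on an aromatic carbon. Chloro on the same ring in compound 3 stayed at the limit, while fluoro in compound 2 brought a gain, so the two measured steps pull in opposite directions and neither carries chloro where compound 4 does. The expected step of an at least 1.7-fold lower number from compound 1 to compound 4 (0.24 log units; that floor lies within the scatter) is therefore small and uncertain. Compound 4 is estimated at 45000 nM, within 15000 nM to 120000 nM.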

Compound 4, half-maximal inhibitory concentration: 56500 nM
Compound 4: the middle estimate sits 1.3-fold (0.10 log units) below what was measured, and the stated range covers the measured number.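

Among the compounds shown here, with 3-chlorophenyl in place of phenyl, a chloro compound gains a readable value in this assay for the first time, and the change appears as an at least 1.4-fold lower number from compound 1 to compound 4 (0.15 log units; that floor lies within the scatter), while 3-chlorophenyl in place of 2-chlorophenyl appears as an at least 1.4-fold lower number from compound 3 to compound 4 (0.15 log units; that floor lies within the scatter). Both of these are floors rather than sizes, and neither floor clears the scatter, because the two starting compounds give only a limit: the limit of > 80000 nM in this assay, at which 2 of the 4 values shown sit. Against the 4-fluorophenyl group, the 3-chlorophenyl group falls back, with a 3.3-fold higher number from compound 2 to compound 4 (0.51 log units; beyond the scatter), so this chloro position does not match the fluoro compound.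

The compounds shown leave open whether 4-chlorophenyl would match the 4-fluorophenyl group of compound 2. They also leave open how 3-fluorophenyl, or an amine or a methoxy group on the same ring, would read.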